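Nitro-to-amino switch on two rearranged dithiole cores

The compounds below may be only part of what the source reports. "The series", "measured", "known", "first", "only" and "open" are said of these compounds alone.

Compound 1 `COc1ccc(-c2ssc(=O)c2-c2cc(OC)c(OC)c(OC)c2)cc1[N+](=O)[O-]` and compound 2 `COc1ccc(-c2ssc(=O)c2-c2cc(OC)c(OC)c(OC)c2)cc1N` share one core and differ only at a single aromatic carbon. In a functional assay on KB cells (Homo sapiens) for antiproliferative activity, read by MTT assay, with a stated time of 72 h (a higher number here means a weaker inhibitor, a lower number a stronger inhibitor), compound 1 gives 22300 nM, and in this assay compound 2 gives 60 nM. The change is amino in place of nitro on an aromatic carbon and the step it made was a 370-fold lower number from compound 1 to compound 2 (2.57 log units; beyond the scatter).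

Compound 3 `COc1ccc(-c2c(-c3cc(OC)c(OC)c(OC)c3)ssc2=O)cc1[N+](=O)[O-]` is built from the same atoms as compound 1, joined differently; the difference between the two cores is not broken down here. In this assay compound 3 gives only a limit, > 100000 nM, and not a number. That limit is the one described by the limit of > 100000 nM in this assay, at which 1 of the 3 values shown sits.

Compound 4 `COc1ccc(-c2c(-c3cc(OC)c(OC)c(OC)c3)ssc2=O)cc1N` stands to compound 3 as compound 2 stands to compound 1: the change is amino in place of nitro on an aromatic carbon, which is the same change, at a place described in the same words. Compound 4 has not yet been measured in this assay.

For compound 4 the expected step is an at least 66-fold lower number from compound 3 to compound 4 (1.82 log units; beyond the scatter), which rests on the step seen from compound 1 to compound 2, a 370-fold lower number from compound 1 to compound 2 (2.57 log units; beyond the scatter), applied to a starting point that is known only as a limit. Since the value of compound 3 may lie anywhere past that limit, the expectation for compound 4 is wide. The estimate for compound 4 in this assay is 1500 nM, with a range expected from 150 nM to 40000 nM.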

Compound 4, half-maximal inhibitory concentration: > 100000 nM
Compound 4: only a limit was reported; the forecaster's own chance of this, stated with the estimate: 15%; middle value at least 66-fold (1.82 log units) away from the limit.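

In this assay compound 4 gives > 100000 nM, which is a limit and not a number. Compound 3 is also known only as a limit, so no step can be read between compound 3 and compound 4. The two compounds share one limit: the limit of > 100000 nM in this assay, at which 2 of the 4 values shown sit. The compounds shown leave open whether amino in place of nitro changes the number at all on the core of compound 3.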